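The source may hold more compounds than are shown below. What is called first, only, known or untested is meant among the compounds shown, and "the series" means these compounds.

Measured so far:
compound 1 `C[C@@H](O)[C@H]1C(=O)N2C(C(=O)OCOC(=O)OC(C)(C)C)=C(S[C@@H]3CN[C@H](C(=O)Nc4cccc(C(=O)O)c4)C3)[C@H](C)[C@H]12` — > 95% 
compound 2 `C[C@@H](O)[C@H]1C(=O)N2C(C(=O)OCOC(=O)OC(C)(C)C)=C(S[C@@H]3CN[C@H](C(=O)Nc4cccc(C(=O)OCOC(=O)OC(C)(C)C)c4)C3)[C@H](C)[C@H]12` — > 95% 
compound 3 `CC(C)C(=O)OCOC(=O)c1cccc(NC(=O)[C@@H]2C[C@H](SC3=C(C(=O)O)N4C(=O)[C@H]([C@@H](C)O)[C@H]4[C@H]3C)CN2)c1` — > 95% 

In an ADME assay for metabolic stability, read by LC-MS, with a stated time of 3 h, at pH 6.5, tested at 50 uM (a lower number here means that less of the compound is left, a higher number that more of the compound is left), compound 1 gives > 95%, which is a limit of the assay and not a number. Compound 2 gives > 95%, also a limit. Compound 3 gives > 95%, again a limit. Among the measured compounds shown here, every value so far therefore sits at the same ceiling, as the limit of > 95% in this assay, at which 3 of the 3 values shown sit, records, and the only single-change step, a step that the two limits leave unreadable from compound 1 to compound 2, cannot be read in size or direction.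

Compound 4 `CCOC(=O)C1=C(S[C@@H]2CN[C@H](C(=O)Nc3cccc(C(=O)O)c3)C2)[C@H](C)[C@@H]2[C@@H]([C@@H](C)O)C(=O)N12` has not yet been measured. It differs from compound 1 by methyl in place of (tert-butoxycarbonyl)oxy on a saturated chain carbon bound to an oxygen next to a carbonyl group. For the measured compounds named here, no measured step bears on this change, and the one step recorded is unreadable, so there is no basis for expecting a shift in either direction beyond the scatter. Since compound 1 sits at the limit > 95%, compound 4 is expected to land near that ceiling as well. The step of a number at least 2 percentage points lower from compound 1 to compound 4 (that floor lies within the scatter) is expected to be none beyond the scatter. Compound 4 is estimated at 93%, between 80% and 99%.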

Compound 4, percent of the compound remaining: > 95%
Compound 4: only a limit was reported (the forecaster's own chance of this, stated with the estimate: 60%); at least 2 percentage points between middle value and limit.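

In this assay compound 4 gives > 95%, which is a limit and not a number, so the step from compound 1 to compound 4 cannot be read in size or direction. The compounds shown leave open whether any of these changes alters how much compound remains, because all of them share one ceiling: the limit of > 95% in this assay, at which 4 of the 4 values shown sit.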